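One Ring Swap, Solubility Awaited

A few compounds are considered here, and "the series" means these few. Any claim that something is new, unique, unknown or untested is made for them only; others in the source may bear on it.

Of the compounds shown here, two have been measured in a physicochemical assay for solubility, read by HPLC, measured as thermodynamic solubility, with a stated time of 4 h, at pH 6.8; a lower number here means a less soluble compound, a higher number a more soluble compound. Compound 1 `Cc1ccc(Oc2ccc3nc(COc4cccc(C(=O)O)c4)n(C)c3n2)cc1` gives 33 ug/mL. Compound 2 `Cn1c(COc2cccc(C(=O)O)c2)nc2ccc(Oc3cccc(Cl)n3)cc21` gives 7.7 ug/mL, the lower of the two numbers, and its gap to compound 1 lies beyond the scatter. Compound 3 `Cn1c(COc2cccc(C(=O)O)c2)nc2ccc(Oc3ncc(Cl)cc3F)cc21` differs from compound 2 in one place: 5-chloro-3-fluoropyridin-2-yl in place of 6-chloropyridin-2-yl on an oxygen on an aromatic ring. Among the measured compounds shown here, no measured pair shows what such a change does in this assay, so only a small step is expected, likely within the scatter, perhaps a slight drop. Compound 3 is estimated at 6 ug/mL, within 2 ug/mL to 18 ug/mL. The expected step is a 1.3-fold lower number from compound 2 to compound 3 (0.11 log units; within the scatter).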

Compound 3, solubility: 10 ug/mL
The estimate for compound 3 lay 1.7-fold (0.22 log units) below the measured number; the measured number falls inside the stated range.
By their numbers in this assay, from the lowest: compounds 2 and 3 (each within the scatter of the next); then compound 1.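

In this assay the swap of 6-chloropyridin-2-yl for 5-chloro-3-fluoropyridin-2-yl on this oxygen gives a 1.3-fold higher number from compound 2 to compound 3 (0.11 log units; within the scatter) and so has no readable effect on the number. Among the compounds shown here, this is the first measured pair for this position, and it shows that this particular change leaves the two compounds indistinguishable in this measurement. No measurement shown here explains the result.

Going by these compounds, whether a larger step is possible at this position remains open. A pyridine ring carrying an amine or a carboxylic acid in place of the halogens could answer that.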